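Methyl in place of cyano on compound 3

The compounds below may be only part of what the source reports. "The series", "measured", "known", "first", "only" and "open" are said of these compounds alone.

In an ADME assay on MT4 cells (Homo sapiens) for cytotoxicity, read by MTT assay, with a stated time of 5 days (on this read-out higher numbers stand for lower toxicity in this test and lower numbers for higher toxicity in this test), compound 3 `COc1cc(Oc2c(C)cc(C)cc2C)cc(Nc2ccc(C#N)cc2)n1` gives 29000 nM. Compound 2 `COc1cc(Oc2cc(C)cc(C)c2)cc(Nc2ccc(C#N)cc2)n1` gives 20000 nM. The step between them is a 1.5-fold higher number from compound 2 to compound 3 (0.16 log units; within the scatter), so the two values stand level. Compound 1 `COc1cc(Oc2c(C)cc(C#N)cc2C)cc(Nc2ccc(C#N)cc2)n1` gives > 147000 nM, and this value is a limit of the assay.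

The next structure is compound 4 `COc1cc(Oc2c(C)cc(C)cc2C)cc(Nc2ccc(C)cc2)n1`, which differs from compound 3 in one place, para to a large group: methyl in place of cyano on an aromatic carbon.

Two measured steps can be weighed. The one of the same kind is an at least 5.0-fold lower number from compound 1 to compound 3 (0.70 log units; beyond the scatter), again methyl in place of cyano on an aromatic carbon, although at a different carbon of the shared core. The other, a 1.5-fold higher number from compound 2 to compound 3 (0.16 log units; within the scatter), concerns a different group and offers little guidance here. The swap on compound 4 therefore has one precedent, and that precedent points toward a lower number in this assay. Since the swap sits at a different carbon, only part of that size is expected to carry over. The expected change is a 2.1-fold lower number from compound 3 to compound 4 (0.32 log units; beyond the scatter), a modest move in the same direction. The estimate for compound 4 is 14000 nM, expected to fall between 5000 nM and 35000 nM.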

Compound 4, half-maximal cytotoxic concentration: 35000 nM
The estimate for compound 4 lay 2.5-fold (0.40 log units) below the measured number, and the stated range covers the measured number.
By their numbers in this assay, from the lowest: compounds 2, 3 and 4 (each within the scatter of the next). At a limit, above all of these: compound 1.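

In this assay, the (4-cyanophenyl)amino part of compound 3 can give way to (4-methylphenyl)amino with the two numbers standing level, a 1.2-fold higher number from compound 3 to compound 4 (0.08 log units; within the scatter), so at this carbon, para to a large group, the nitrile shows no readable link to the number. The same swap at the other carbon of the shared core reads differently, an at least 5.0-fold lower number from compound 1 to compound 3 (0.70 log units; beyond the scatter), which shows that the earlier step does not carry over as a single size for methyl in place of cyano across these two carbons. Compound 1 stands at a limit, so the size of that earlier step is fixed from one side only: the limit of > 147000 nM in this assay, at which 1 of the 4 values shown sits.

Whether an amine, a carboxylic acid or a longer chain at this same carbon would also leave the number level with compound 3 remains open, since cyano and methyl are the only two groups shown there. It is equally open whether the swap would read the same with the 3,5-dimethylphenyl group of compound 2 on the oxygen, and the compounds shown give no cause for the difference between the two carbons.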